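This account rests on a few compounds, and the source may have more. Where it says the series, first, only, none or still open, it means among the compounds named here.

Measured compounds:
compound 1 `Cc1ccc(OCC(=O)N(Cc2cccs2)C2COC2)cc1`; in an assay on HEK293 cells for agonist activity at transient receptor potential cation channel subfamily M member 8 (Homo sapiens), read by fluorescence and calcium flux, with a stated time of 15 min (a higher number here means that more compound is needed for the effect, a lower number that less compound is needed), compound 1 gives 23000 nM.
compound 2 `Cc1ccc(OCC(=O)N(Cc2cccs2)C(C)(C)C)cc1`; in this assay compound 2 gives 11000 nM.
compound 3 `Cc1ccc(OCC(=O)N(Cc2cccs2)C(C)C)cc1`; in this assay compound 3 gives 70 nM.

Compound 3 stands at the lowest number of the three. The steps leading to it are large: a 160-fold lower number from compound 2 to compound 3 (2.20 log units; beyond the scatter) and a 330-fold lower number from compound 1 to compound 3 (2.52 log units; beyond the scatter). The remaining step is only modest: a 2.1-fold lower number from compound 1 to compound 2 (0.32 log units; beyond the scatter). All three measured changes sit on the same amide-type nitrogen, and the numbers show that this position is very sensitive; of the three groups tried there, only isopropyl gives a low number, while the ring (oxetan-3-yl) and tert-butyl both give high numbers.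

Compound 4 `Cc1ccc(OCC(=O)N(Cc2cccs2)c2c(C)n[nH]c2C)cc1` differs from compound 3 by 3,5-dimethyl-1H-pyrazol-4-yl in place of isopropyl on an amide-type nitrogen. Among the measured compounds shown here, the entering group is a ring, as oxetan-3-yl was in compound 1, and it carries a hydrogen-bond donor and acceptor that none of the measured groups at this position has. For the measured compounds named here, no measured step tests an aromatic ring here, so the direction is uncertain, but every departure from isopropyl among the measured compounds has given a large rise in this assay. A large rise is therefore expected, a 43-fold higher number from compound 3 to compound 4 (1.63 log units; beyond the scatter). Compound 4 is estimated at 3000 nM, with a range of 300 nM to 30000 nM.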

Compound 4, half-maximal effective concentration: 0.3 nM
Beside the measured number, compound 4's estimate is 10000-fold (4.00 log units) above it; the whole stated range lies above it.
By their numbers in this assay, from the lowest: compound 4; then compound 3; then compound 2; then compound 1.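

Working notes on the amide-type nitrogen: in this assay, 3,5-dimethyl-1H-pyrazol-4-yl gives a 230-fold lower number from compound 3 to compound 4 (2.37 log units; beyond the scatter) and so, of the groups shown at this position, replaces isopropyl as the one with the lowest number. A ring at this position is therefore compatible with a low number, since the same change from the other ring shown gives a 77000-fold lower number from compound 1 to compound 4 (4.88 log units; beyond the scatter), and the high number with tert-butyl sets no general ceiling on group size, since the entering group has 7 heavy atoms against 3 for isopropyl and gives a 37000-fold lower number from compound 2 to compound 4 (4.56 log units; beyond the scatter) as the step from tert-butyl. No data are available here that bear on the reason for these steps.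

The compounds shown do not separate the contributions of the aromatic ring, the two ring methyl groups and the ring hydrogen-bond donor and acceptor; 1H-pyrazol-4-yl without its methyl groups, 3,5-dimethylisoxazol-4-yl and 2,6-dimethylphenyl at the same nitrogen would address that. From the compounds shown here alone, it also remains open whether the low number persists when the thiophen-2-ylmethyl group on this nitrogen is exchanged for benzyl.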